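The source may hold more compounds than are shown below. What is called first, only, known or untested is meant among the compounds shown, and "the series" means these compounds.

Going by the values given here, in an ADME assay for permeability, using PAMPA, at pH 5.5 (on this read-out lower numbers stand for lower permeability and higher numbers for higher permeability), compound 1 `Cn1cc(-c2ccc(C(F)(F)F)cc2)c2cc(F)c(C(=O)NS(=O)(=O)C3CC3)cc21` gives 1660 nm/s, the highest of the two numbers measured so far. Compound 2 `Cn1cc(-c2ccc(C(F)(F)F)cc2)c2ccc(C(=O)NS(=O)(=O)C3CC3)cc21` gives 525 nm/s. The change between them, hydrogen in place of fluoro on an aromatic carbon, is a 3.2-fold lower number from compound 1 to compound 2 (0.50 log units; beyond the scatter), a modest step beyond the scatter.

Compound 3 `Cn1cc(-c2ccc(C(F)(F)F)cc2)c2cc(F)c(C(=O)NS(C)(=O)=O)cc21` has not yet been measured in this assay. It keeps the fluoro of compound 1 and differs elsewhere: methyl in place of cyclopropyl on a sulfonyl sulfur, in words methyl in place of cyclopropyl on a sulfonyl sulfur. Among the compounds with values here, no measured step touches this group, so the data offer no direct guide to it. Within the data shown here, the only measured step, a 3.2-fold lower number from compound 1 to compound 2 (0.50 log units; beyond the scatter), lies at another place and serves merely as a yardstick for what one small edit has done here. A step no larger than that one is therefore expected, most likely a small fall that may stay within the scatter. The estimated step is a 1.5-fold lower number from compound 1 to compound 3 (0.18 log units; within the scatter). For compound 3 the expected value is 1100 nm/s, with an expected range from 450 nm/s to 2300 nm/s.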

Compound 3, apparent permeability: 712 nm/s
Compound 3: middle estimate off by 1.5-fold (0.19 log units), on the high side; measured number inside the range.
By their numbers in this assay, from the lowest: compounds 2 and 3 (each within the scatter of the next); then compound 1.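

In this assay the sulfonyl sulfur now proves to be a second place where one small edit moves the number beyond the scatter: with methyl in place of cyclopropyl, the result is a 2.3-fold lower number from compound 1 to compound 3 (0.37 log units; beyond the scatter) for this pair. The earlier compounds shown here showed such a step only for the fluoro on the aromatic carbon, and they left the group on the sulfonyl sulfur untested. Compound 1 now stands above each of the two compounds that differ from it in one place, so neither the loss of the fluoro nor the replacement of cyclopropyl keeps its number, although nothing available explains the fall on the sulfonyl side.

With only cyclopropyl and methyl shown on the sulfonyl sulfur, it remains open whether a longer chain such as ethyl or propyl, a larger ring such as cyclobutyl, or an amine such as dimethylamino would stay close to compound 1 or fall further. It also remains open how the two edits behave together, since the compounds shown do not pair methyl on the sulfonyl sulfur with hydrogen in place of the fluoro.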